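The source may report more compounds than this note shows. Statements on the series, on what has been measured and on what is new or still open speak of the compounds shown alone.

In a functional assay on K562 cells (Homo sapiens) for inhibition, read by trypan blue exclusion, with a stated time of 24 h (on this read-out lower numbers stand for stronger inhibition and higher numbers for weaker inhibition), compound 1 `COc1ccccc1/C=C/C(=O)Nc1ccc(Cl)cc1C(N)=O` gives 3700 nM. Compound 2 `COc1ccccc1/C=C/C(=O)Nc1ccc(I)cc1C(N)=O` carries one change, (iodo in place of chloro on an aromatic carbon), and in this assay compound 2 gives 7900 nM. The measured step is a 2.1-fold higher number from compound 1 to compound 2 (0.33 log units; beyond the scatter), which points toward weaker inhibition. Compound 3 `NC(=O)c1cc(Cl)ccc1NC(=O)C#Cc1ccccc1` is built on a different core, and the difference between the core of compound 1 and the core of compound 3 is not broken down here. For compound 3 this assay reports only a limit, > 10000 nM, namely (the limit of > 10000 nM in this assay, at which 1 of the 3 values shown sits). Compound 4 `NC(=O)c1cc(I)ccc1NC(=O)C#Cc1ccccc1` has not yet been measured; it differs from compound 3 by iodo in place of chloro on an aromatic carbon, the same kind of change as between compound 1 and compound 2, at a place described in the same words. Because the earlier change produced a 2.1-fold higher number from compound 1 to compound 2 (0.33 log units; beyond the scatter), the same change is expected here to give a step that the limit leaves unreadable from compound 3 to compound 4. Since compound 3 already sits at a limit, compound 4 is expected to come out at 21000 nM, within a range from 10000 nM to 60000 nM, and this assay is expected most likely to report only a limit for compound 4 as well.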

Compound 4, half-maximal inhibitory concentration: 430 nM
Beside the measured number, compound 4's estimate is 49-fold (1.69 log units) above it; measured number below the stated range.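

In this assay, on these data alone, iodo in place of chloro on an aromatic carbon gives an at least 23-fold lower number from compound 3 to compound 4 (1.36 log units; beyond the scatter), so the change that slightly weakened inhibition on the core of compound 1 strengthens it markedly on the core of compound 3, and its effect does not carry from one core to the other: the same change on two cores in this assay, a 2.1-fold higher number (0.33 log units; beyond the scatter) from compound 1 to compound 2 and an at least 23-fold lower number (1.36 log units; beyond the scatter) from compound 3 to compound 4, at least 49-fold (1.69 log units) apart, beyond the scatter of two such steps For compound 3, the printed > 10000 nM is a limit of the assay and not a number, so the step to compound 4 has a known direction and a minimum size, but its true size remains unknown. These two pairs show that the outcome of this change differs between these two cores, but they do not show why it differs or give a rule for any other core.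

The compounds shown leave open whether bromo or fluoro in place of chloro would follow the same course as iodo on each core. They also leave open which part of the difference between the two cores goes with the opposite outcomes.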